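A few compounds are considered here, and "the series" means these few. Any claim that something is new, unique, unknown or untested is made for them only; others in the source may bear on it.

Compound 1 `COC(=O)Cn1c(=O)c(S(=O)(=O)c2ccc(F)cc2F)cc2cnc(Nc3ccc4[nH]ccc4c3)nc21`: 5000 nM
Compound 2 `Cn1c(=O)c(S(=O)(=O)c2ccccc2)cc2cnc(Nc3cnc4[nH]ccc4c3)nc21`: 5000 nM
Compound 3 `Cn1c(=O)c(C(=O)Nc2ccc(F)cc2)cc2cnc(Nc3ccc4[nH]ccc4c3)nc21`: 5000 nM

All three compounds were tested in a functional assay on K562 cells (Homo sapiens) for inhibition, read by trypan blue exclusion, with a stated time of 72 h; a lower number here means a stronger inhibitor, a higher number a weaker inhibitor. Compound 3, at 5000 nM, stands level with compounds 1 and 2, so the numbers separate none of them. Within the data shown here, the measured set also contains no pair differing in one place, which leaves no measured step to carry over.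

The next compound is compound 4 `Cc1ccc(S(=O)(=O)c2cc3cnc(Nc4ccc5[nH]ccc5c4)nc3n(C)c2=O)cc1`, which has not yet been measured in this assay. Relative to compound 3, it has (4-methylphenyl)sulfonyl in place of (4-fluorophenyl)carbamoyl on an aromatic carbon of a six-membered aromatic ring with 1 nitrogen: (4-methylphenyl)sulfonyl in place of (4-fluorophenyl)carbamoyl on an aromatic carbon.

The closest guides are two compounds that also carry a sulfonyl group with an aromatic ring on it. Compound 1 gives 5000 nM, and compound 2 gives 5000 nM. Neither value suggests that exchanging the carbamoyl group for a sulfonyl group should move the result much, so no change beyond the scatter is expected. The expected step is a 1.4-fold lower number from compound 3 to compound 4 (0.15 log units; within the scatter), which is an estimate only. For compound 4, the estimated value in this assay is 3500 nM, with an expected range of 700 nM to 10000 nM.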

Compound 4, half-maximal inhibitory concentration: 750 nM
Estimate against measurement, compound 4: 4.7-fold (0.67 log units) above; the measured number falls inside the stated range.
By their numbers in this assay, from the lowest: compound 4; then compounds 1, 2 and 3 (each within the scatter of the next).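

In this assay, among these compounds, (4-methylphenyl)sulfonyl in place of (4-fluorophenyl)carbamoyl on this aromatic carbon gives a 6.7-fold lower number from compound 3 to compound 4 (0.82 log units; beyond the scatter), the first step in the set that can be read between compounds differing in one place. It shows that the result responds to the group at this position, which the three equal earlier values could not show. The two groups each carry a six-membered aromatic ring of carbon only, but the sulfonyl and carbamoyl links and the methyl and fluorine on the ring change together, so the step cannot be assigned to either part, and nothing in hand explains why the number falls.

A (4-fluorophenyl)sulfonyl group on the core of compound 4 would separate these two parts of the change, while a methoxy group or an amine on the ring of the sulfonyl group would test how far the ring's substituent matters. Also open, on these data alone, is whether the step holds with a longer chain on the ring nitrogen in place of the methyl group of compound 4.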